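This account rests on a few compounds, and the source may have more. Where it says the series, first, only, none or still open, it means among the compounds named here.

Measured so far:
compound 1, `O=C(CCc1ccccc1)Nc1nc2ccccc2c(=O)s1` — 17.6 nM
compound 2, `COc1cccc(CCC(=O)Nc2nc3ccccc3c(=O)s2)c1` — 95.3 nM
compound 3, `O=C(CCCc1ccccc1)Nc1nc2ccc(Cl)cc2c(=O)s1` — > 10000 nM

In an in vitro assay on cells for inhibition of Amine oxidase [flavin-containing] B (Homo sapiens), read by fluorescence and Amplex Red, with stated times of 30 min and 45 min (on this read-out higher numbers stand for weaker inhibition and lower numbers for stronger inhibition), compound 1 gives 17.6 nM and compound 2 gives 95.3 nM. For compound 3 only a limit is reported, > 10000 nM, so its true value is not known; it sits at the limit of > 10000 nM in this assay, at which 1 of the 3 values shown sits. Going by the values given here, the one measured step, a 5.4-fold higher number from compound 1 to compound 2 (0.73 log units; beyond the scatter), concerns a methoxy group on the phenyl ring and does not touch the change now at hand.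

Compound 4, `O=C(CCCc1ccccc1)Nc1nc2ccccc2c(=O)s1`, differs from compound 3 by hydrogen in place of chloro on an aromatic carbon. Among the compounds with values here, no measured step shows what removing this chloro does on this core, so the expectation rests on weak ground. Compound 3 gives only a limit. Compound 1, which carries the shorter chain and no chloro, gives 17.6 nM. A move back toward a measurable number is expected, an at least 6.6-fold lower number from compound 3 to compound 4 (0.82 log units; beyond the scatter). Compound 4 is therefore estimated at 1500 nM, within 150 nM to 10000 nM.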

Compound 4, half-maximal inhibitory concentration: 34.9 nM
Compound 4: the middle estimate sits 43-fold (1.63 log units) above what was measured; measured number outside the range, below it.
By their numbers in this assay, from the lowest: compounds 1 and 4 (each within the scatter of the next); then compound 2. At a limit, above all of these: compound 3.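

Taking the chloro away from the aromatic carbon, meta to a fused ring and para to a fused ring, gives by far the largest change seen so far in this assay: an at least 280-fold lower number from compound 3 to compound 4 (2.45 log units; beyond the scatter). From the compounds shown here alone, the real size of this step stays unknown, since compound 3 stands at a limit and not at a number: the limit of > 10000 nM in this assay, at which 1 of the 4 values shown sits. The chain matters much less here, as benzyl in place of phenyl gives a 2.0-fold higher number from compound 1 to compound 4 (0.30 log units; within the scatter), while benzyl in place of 3-methoxyphenyl gives a 2.7-fold lower number from compound 2 to compound 4 (0.44 log units; beyond the scatter).

Going by these compounds, whether chloro at this aromatic carbon has the same effect with the shorter chain of compound 1 remains open, as does whether fluoro, methyl or methoxy there would behave more like hydrogen or like chloro. Also open, on these data alone, is how a still longer chain, or an amine on the phenyl ring, would read.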